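The compounds below may be only part of what the source reports. "The series", "measured", "known", "first", "only" and "open" are said of these compounds alone.

Of the compounds shown here, three from this series have been measured in a functional assay on HeLa cells (Homo sapiens) for cytotoxicity, read by WST assay, with a stated time of 48 h; on this read-out higher numbers stand for weaker inhibition and lower numbers for stronger inhibition. Compound 1 `Cc1ccc(/C=C/C[C@H]2C[C@@H]([C@@H](O)c3ccccc3)CO[C@@H]2c2ccccc2)cc1C` gives 10000 nM. Compound 2 `Oc1cccc(/C=C/C[C@H]2C[C@@H]([C@@H](O)c3ccccc3)CO[C@@H]2c2ccccc2)c1` gives 18600 nM in this assay, while compound 3 `COc1cccc([C@H]2OC[C@H]([C@@H](O)c3ccc(OC)c(OC)c3)C[C@@H]2C/C=C/c2ccc(OC)c(OC)c2)c1` gives 21800 nM. Among these three numbers compound 2 stands second highest; its nearest neighbour is compound 3 and its furthest is compound 1, and both gaps lie within the scatter. Among the measured compounds shown here, the only single-point step so far, a 1.9-fold higher number from compound 1 to compound 2 (0.27 log units; within the scatter), is also within the scatter.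

Compound 4 `O=[N+]([O-])c1ccccc1/C=C/C[C@H]1C[C@@H]([C@@H](O)c2ccccc2)CO[C@@H]1c1ccccc1` has not yet been measured in this assay. It differs from compound 2 in one place: 2-nitrophenyl in place of 3-hydroxyphenyl on a double-bonded chain carbon bound to a double-bonded chain carbon. For the measured compounds named here, the one step that bears on this change is a 1.9-fold higher number from compound 1 to compound 2 (0.27 log units; within the scatter), where a different group on the same double-bonded chain carbon bound to a double-bonded chain carbon left the number within the scatter. On that basis no step beyond the scatter is expected from compound 2 to compound 4, a 1.2-fold lower number from compound 2 to compound 4 (0.09 log units; within the scatter). Compound 4 is therefore estimated at 15000 nM in this assay, with a range from 6000 nM to 40000 nM.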

Compound 4, half-maximal inhibitory concentration: 11800 nM
The estimate for compound 4 lay 1.3-fold (0.10 log units) above the measured number; the measured number falls inside the stated range.
By their numbers in this assay, from the lowest: compounds 1, 4, 2 and 3 (each within the scatter of the next, the first and the last beyond it).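

In this assay, the 2-nitrophenyl group on this double-bonded chain carbon gives a 1.6-fold lower number from compound 2 to compound 4 (0.20 log units; within the scatter) and a 1.2-fold higher number from compound 1 to compound 4 (0.07 log units; within the scatter), so both steps stay within the scatter. The position therefore tolerates a third aryl group, one that brings in a nitrogen and carries no hydrogen-bond donor, and 3,4-dimethylphenyl, 3-hydroxyphenyl and 2-nitrophenyl cannot be told apart here. No measurement given here explains this flat result.

The compounds shown leave open whether an amine or a carboxylic acid on this aromatic ring would produce a step beyond the scatter. They also do not show whether a longer chain between the ring and the shared core would do so.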